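Adding Fluoro to a Compound with a Narrow Value Gap

This account rests on a few compounds, and the source may have more. Where it says the series, first, only, none or still open, it means among the compounds named here.

compound 1 `O=C(/C=C/c1ccc(F)cc1)Nc1nnc(-c2ccccc2)s1` gives 1.82 ug/mL
compound 2 `Cc1ccc(-c2nnc(NC(=O)/C=C/c3ccccc3)s2)cc1` gives 1.38 ug/mL

In a functional assay on A549 cells (Homo sapiens) for antiproliferative activity, read by MTT assay, with a stated time of 48 h (on this read-out lower numbers stand for stronger inhibition and higher numbers for weaker inhibition), compound 2 stands at 1.38 ug/mL and compound 1 at 1.82 ug/mL. These two values lie within the usual scatter of each other, so the numbers do not separate the two compounds.

Compound 3 `Cc1ccc(-c2nnc(NC(=O)/C=C/c3ccc(F)cc3)s2)cc1` is built from compound 2 by one change (fluoro in place of hydrogen on an aromatic carbon). It carries fluoro in place of hydrogen on an aromatic carbon, para to a large group, so that phenyl becomes 4-fluorophenyl.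

Going by the values given here, no measured pair here differs in a single place, so the data give no direct measure of this change. Among the compounds with values here, the only guide is the close agreement of compound 1 (1.82 ug/mL) and compound 2 (1.38 ug/mL), and it suggests no large movement in this assay. The expected step of a 1.1-fold higher number from compound 2 to compound 3 (0.04 log units; within the scatter) stays within the scatter, with no direction favoured. The estimate for compound 3 is 1.5 ug/mL with an expected range of 0.7 ug/mL to 3.2 ug/mL on repeated measurement.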

Compound 3, half-maximal inhibitory concentration: 1.23 ug/mL
Compound 3: the middle estimate sits 1.2-fold (0.09 log units) above what was measured; measured number inside the range.
By their numbers in this assay, from the lowest: compounds 3, 2 and 1 (each within the scatter of the next).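

In this assay, fluoro in place of hydrogen on an aromatic carbon, para to a large group, now has a direct reading: a 1.1-fold lower number from compound 2 to compound 3 (0.05 log units; within the scatter). The same compound gives a direct reading of a second change, the addition of a methyl group with the 4-fluorophenyl held constant, at a 1.5-fold lower number from compound 1 to compound 3 (0.17 log units; within the scatter), so neither single change separates the compounds it joins in this assay. Nothing available speaks to what lies behind these two readings.

The compounds shown carry only hydrogen or fluoro at the first place and only hydrogen or methyl at the second, so they test a narrow range of groups at each. From the compounds shown here alone, whether an amine or a carboxylic acid in place of the fluoro, or a longer chain such as propyl in place of the methyl, would give a step beyond the scatter remains open.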